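Swapping an Acid Tail on a Bile Acid Receptor Agonist

A few compounds are considered here, and "the series" means these few. Any claim that something is new, unique, unknown or untested is made for them only; others in the source may bear on it.

Three compounds share one core and differ only in the acid-bearing tail. In an assay on isolated protein for agonist activity at Bile acid receptor (Homo sapiens), read by FRET (on this read-out lower numbers stand for an effect already at smaller amounts and higher numbers for an effect only at larger amounts of compound), compound 1 `CS(=O)(=O)NC(=O)c1ccc(C2CC2c2ccc(OCc3c(-c4c(Cl)cccc4Cl)noc3C3CC3)cc2Cl)cc1` gives 90 nM, compound 2 `O=C(O)CNC(=O)c1ccc(C2CC2c2ccc(OCc3c(-c4c(Cl)cccc4Cl)noc3C3CC3)cc2Cl)cc1` gives 150 nM, and compound 3 `O=C(O)c1cccc(C2CC2c2ccc(OCc3c(-c4c(Cl)cccc4Cl)noc3C3CC3)cc2Cl)c1` gives 32 nM. Compound 2 thus carries the highest of the three numbers, though its gap to compound 1 lies within the scatter and only compound 3 lies beyond it. Among the compounds with values here, the one single-point step recorded, a 1.7-fold higher number from compound 1 to compound 2 (0.22 log units; within the scatter), exchanges the group on the same amide nitrogen and stays within the scatter. Compound 4 `O=C(NCCS(=O)(=O)O)c1ccc(C2CC2c2ccc(OCc3c(-c4c(Cl)cccc4Cl)noc3C3CC3)cc2Cl)cc1` carries sulfomethyl in place of carboxy on a saturated chain carbon bound to an amide-type nitrogen, one acid group for another on that tail. Because a 1.7-fold higher number from compound 1 to compound 2 (0.22 log units; within the scatter) stayed within the scatter, a similarly small step is expected, no change at the digits printed from compound 2 to compound 4 (within the scatter). Compound 4 is therefore expected near 150 nM, between 60 nM and 400 nM.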

Compound 4, half-maximal effective concentration: 76 nM
Compound 4: middle estimate off by 2.0-fold (0.30 log units), on the high side; the measured number falls inside the stated range.
By their numbers in this assay, from the lowest: compound 3; then compounds 4, 1 and 2 (each within the scatter of the next).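

Exchanging carboxy for sulfomethyl on a saturated chain carbon bound to an amide-type nitrogen gives a 2.0-fold lower number from compound 2 to compound 4 (0.30 log units; within the scatter), so in this assay this place takes a second kind of acid group without a change that stands clear of the scatter. Compared with methylsulfonyl on the amide-type nitrogen, 2-sulfoethyl gives a 1.2-fold lower number from compound 1 to compound 4 (0.07 log units; within the scatter), which leaves all three of these tails within the scatter of one another. No available evidence bears on why these numbers stay so close. As far as these compounds go, whether a longer chain carrying the sulfo group, or an amine in place of the acid, would keep the number in this range remains open.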